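Trifluoromethyl Added to the Phenyl of Compound 3

This account rests on a few compounds, and the source may have more. Where it says the series, first, only, none or still open, it means among the compounds named here.

Compound 1 `COc1ccc(-c2cc3nccc(-c4cc(OC)c(OC)c(OC)c4)n3n2)cc1[N+](=O)[O-]`: > 10000 nM
Compound 2 `COc1cc(-c2cc3nccc(-c4c[nH]c5ccccc45)n3n2)cc(OC)c1OC`: > 10000 nM
Compound 3 `COc1cc(-c2ccnc3cc(-c4ccccc4)nn23)cc(OC)c1OC`: 458 nM

Of the compounds shown here, three have been tested in a functional assay on HeLa cells (Homo sapiens) for inhibition, read by CCK-8 assay, with a stated time of 48 h; on this read-out higher numbers stand for weaker inhibition and lower numbers for stronger inhibition. Compound 1 reaches only a limit of the assay, > 10000 nM. Compound 2 likewise gives only a limit, > 10000 nM. Compound 3 is the one compound with a measured number, 458 nM in this assay; the other two values sit at the limit of > 10000 nM in this assay, at which 2 of the 3 values shown sit, so compound 3 stands alone as the only number shown.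

Compound 4 `COc1cc(-c2ccnc3cc(-c4ccc(C(F)(F)F)cc4)nn23)cc(OC)c1OC` has not yet been measured. It differs from compound 3 in one place: trifluoromethyl in place of hydrogen on an aromatic carbon. Cut one bond further out, the change reads phenyl to 4-(trifluoromethyl)phenyl. Going by the values given here, no measured pair shows what such a change does here, so in this assay no step beyond the usual scatter is expected in either direction. The value of compound 4 is therefore estimated at 500 nM, between 150 nM and 2500 nM, which means an expected step of a 1.1-fold higher number from compound 3 to compound 4 (0.04 log units; within the scatter).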

Compound 4, half-maximal inhibitory concentration: 1840 nM
For compound 4 the middle estimate is 3.7-fold (0.57 log units) below the measured one; low and high end bracket the measured number.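

In this assay, going by these compounds alone, trifluoromethyl in place of hydrogen on the phenyl of compound 3 gives a 4.0-fold higher number from compound 3 to compound 4 (0.60 log units; beyond the scatter), the first step here between two compounds that differ in one place. It shows that this position on the phenyl is not indifferent to what it carries, and that this change weakens inhibition. Compound 4 still gives a measured number, 1840 nM, and nothing shown here accounts for the size of the step.

The compounds shown leave open whether any added group on this carbon weakens inhibition or whether the result is particular to trifluoromethyl, and an amine, a carboxylic acid or a single fluorine at the same place would help to separate the two. They also leave open what trifluoromethyl would do on another carbon of the same phenyl.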